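Swapping methyl for nitro on a low-scoring compound

The source may hold more compounds than are shown below. What is called first, only, known or untested is meant among the compounds shown, and "the series" means these compounds.

Values in a functional assay on HL-60 cells (Homo sapiens) for inhibition, read by CCK-8 assay, with a stated time of 48 h, tested at 20 uM (on this read-out lower numbers stand for less inhibition of growth and higher numbers for more inhibition of growth at the one concentration tested), are as follows
compound 1 `COc1ccc(Cc2nnc(NC(=O)/C(C#N)=C/c3ccccc3OS(=O)(=O)c3ccc([N+](=O)[O-])cc3)s2)cc1` gives 51%
compound 2 `N#C/C(=C\c1ccccc1OS(=O)(=O)c1ccc([N+](=O)[O-])cc1)C(=O)Nc1nnc(Cc2ccc(F)cc2)s1` gives 18%
compound 3 `Cc1ccc(S(=O)(=O)Oc2ccccc2/C=C(\C#N)C(=O)Nc2nnc(Cc3cccc(F)c3)s2)cc1` gives 11%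

Compound 3 stands beyond the scatter from compound 1 but within the scatter of compound 2. Compound 4 `N#C/C(=C\c1ccccc1OS(=O)(=O)c1ccc([N+](=O)[O-])cc1)C(=O)Nc1nnc(Cc2cccc(F)c2)s1` has nitro in place of methyl on an aromatic carbon, para to a large group nitro in place of methyl on an aromatic carbon and is still unmeasured. Among the measured compounds shown here, no measured step makes this change. For the measured compounds named here, the only step, a number 33 percentage points lower from compound 1 to compound 2 (beyond the scatter) with fluoro in place of methoxy, is large but concerns another group, so it bears on this change only weakly. Compound 2, which also carries nitro, gives 18% in this assay and stays within the scatter of compound 3, so a small upward step is expected. The expected step, a number 6 percentage points higher from compound 3 to compound 4 (within the scatter) in this estimate, stays within the scatter. Compound 4 is estimated at 17% (expected range 5% to 38%).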

Compound 4, percent growth inhibition at one concentration: 18%
The estimate for compound 4 lay 1 percentage points below the measured number, within the range that was stated.
By their numbers in this assay, from the lowest: compounds 3, 2 and 4 (each within the scatter of the next); then compound 1.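

In this assay, putting (4-nitrophenyl)sulfonyl in place of (4-methylphenyl)sulfonyl gives a number 7 percentage points higher from compound 3 to compound 4 (within the scatter) and so no clear effect at this position. Likewise, 3-fluorophenyl in place of 4-fluorophenyl gives no change at the digits printed from compound 2 to compound 4 (within the scatter) and so the fluoro position shows no effect between these two compounds. Only the other substituent change stands out: 3-fluorophenyl in place of 4-methoxyphenyl gives a number 33 percentage points lower from compound 1 to compound 4 (beyond the scatter) as a clear drop. From the compounds shown here alone, how an amine or a carboxylic acid on that aromatic carbon would score remains open. Nothing measured here gives a reason for any of these steps.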